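The source may report more compounds than this note shows. Statements on the series, on what has been measured and on what is new or still open speak of the compounds shown alone.

Compound 1 `CC(=O)C1=C(N2CC2)C(=O)C(C)=C(N2CC2)C1=O`, compound 2 `CC1=C(N2CC2)C(=O)C(C(C)COC(N)=O)=C(N2CC2)C1=O`, compound 3 `CCC(COC(N)=O)C1=C(N2CC2)C(=O)C(C)=C(N2CC2)C1=O`, compound 4 `COC(CO)C1=C(N2CC2)C(=O)C(C)=C(N2CC2)C1=O`, not yet measured.

In a functional assay on L1210 cells (Mus musculus), with a stated time of 1 days (a higher number here means a more potent compound, by a factor of ten per unit of this negative logarithm, a lower number a less potent compound), compound 1 gives 3.48, compound 2 gives 5.31 and compound 3 gives 5.2. Compound 2 holds the top number of the three; compound 3 lies within the scatter of it, compound 1 well below. Compound 4 differs from compound 2 in this way: a group of 5 heavy atoms (3 carbon, 2 oxygen; no ring) in place of a group of 7 heavy atoms (4 carbon, 1 nitrogen, 2 oxygen; no ring), on a double-bonded ring carbon. The step that bears on it is a number 1.83 log units higher from compound 1 to compound 2 (beyond the scatter), a change at the same ring carbon; a number 0.11 log units lower from compound 2 to compound 3 (within the scatter) is a change elsewhere and says little here. Because a number 1.83 log units higher from compound 1 to compound 2 (beyond the scatter) was large, the numbers in this assay depend strongly on what sits on that carbon, and a downward step is expected for compound 4, estimated as a number 0.81 log units lower from compound 2 to compound 4 (beyond the scatter). Compound 4 is therefore estimated at 4.5, in a range from 3.8 to 5.2.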

Compound 4, logarithm of the reciprocal of the active concentration, log(1/C): 5.27
Compound 4: the middle estimate sits 0.77 log units below what was measured; the measured number lies above the stated range.
By their numbers in this assay, from the lowest: compound 1; then compounds 3, 4 and 2 (each within the scatter of the next).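

With a number 0.04 log units lower from compound 2 to compound 4 (within the scatter) in this assay, 2-hydroxy-1-methoxyethyl on this double-bonded ring carbon matches the larger group it replaces, so the nitrogen of that group is not needed to hold the number in these compounds. With a number 1.79 log units higher from compound 1 to compound 4 (beyond the scatter), a second group without that nitrogen now stands well clear of acetyl, and the dependence on this position is not tied to one group. No measured data on these compounds explain the result.

As far as these compounds go, whether an amine or a carboxylic acid at this carbon would hold the number remains open. So does the effect of a longer chain carrying the same hydroxyl.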